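The source may hold more compounds than are shown below. What is called first, only, known or untested is meant among the compounds shown, and "the series" means these compounds.

Series notes, core carried through both measured compounds. Compound 1 `NC(=O)c1c(NC(=O)c2ccccc2Cl)sc2c1CCN(Cc1ccccc1)C2` gives 14500 nM in a functional assay on MKN-74 cells (Homo sapiens) for antiproliferative activity, with a stated time of 24 h; a higher number here means a weaker inhibitor, a lower number a stronger inhibitor. Compound 2 `NC(=O)c1c(NC(=O)c2ccc(C(F)(F)F)cc2)sc2c1CCN(Cc1c(Cl)cccc1Cl)C2` gives 8530 nM in this assay. Compound 1 holds the higher of the two numbers, but the gap to compound 2 sits within the scatter, so the two cannot be told apart on these data. For the measured compounds named here, no pair differing in a single place has been measured, so no step size is known.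

Compound 3 `Cc1ccccc1NC(=S)N1CCc2c(sc(NC(=O)c3ccccc3Cl)c2C(N)=O)C1` has not yet been measured. It differs from compound 1 by a group of 10 heavy atoms (8 carbon, 1 nitrogen, 1 sulfur; one six-membered aromatic ring of carbon only) in place of a group of 7 heavy atoms (7 carbon; one six-membered aromatic ring of carbon only), on an amine nitrogen in a ring; the entering group has no common name and brings one hydrogen-bond donor and one hydrogen-bond acceptor where benzyl had none. Going by the values given here, with no measured step to lean on, a move of no more than the scatter is expected in this assay, in either direction. Compound 3 is expected to give 10000 nM, within 3000 nM to 40000 nM, meaning an expected step of a 1.5-fold lower number from compound 1 to compound 3 (0.16 log units; within the scatter).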

Compound 3, half-maximal inhibitory concentration: 11700 nM
Beside the measured number, compound 3's estimate is 1.2-fold (0.07 log units) below it; the measured number falls inside the stated range.
By their numbers in this assay, from the lowest: compounds 2, 3 and 1 (each within the scatter of the next).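

The series now has its first step between compounds differing in one place: on an amine nitrogen in a ring, in this assay the entering group with no common name in place of benzyl gives a 1.2-fold lower number from compound 1 to compound 3 (0.09 log units; within the scatter) as the step size. This step lies within the scatter, so compound 1 and compound 3 cannot be told apart, and at this position benzyl is not required for a number in this range, even with the entering group's added hydrogen-bond donor and acceptor. No evidence beyond the numbers bears on this result.

Going by these compounds, whether a urea, an acetyl group or a chain ending in a carboxylic acid on the same nitrogen would give a step beyond the scatter stays open. So does whether any group here moves the number at all.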